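From allylsulfanyl to propylsulfanyl in the series

This account rests on a few compounds, and the source may have more. Where it says the series, first, only, none or still open, it means among the compounds named here.

Measured so far in a toxicity assay on GES1 cells (Homo sapiens) for inhibition, read by MTT assay, with a stated time of 72 h; on this read-out lower numbers stand for stronger inhibition and higher numbers for weaker inhibition
- compound 1 `Cc1cc(N2CC[C@@H](C)[C@@H](N(C)c3ncnc4[nH]ccc34)C2)n2ncnc2n1` gives 57900 nM
- compound 2 `Cc1cc(N2CC[C@@H](C)[C@@H](N(C)c3ncnc4[nH]ccc34)C2)n2nc(SCC3CCCCC3)nc2n1` gives 98200 nM
- compound 3 `C=CCSc1nc2nc(C)cc(N3CC[C@@H](C)[C@@H](N(C)c4ncnc5[nH]ccc45)C3)n2n1` gives > 100000 nM as a limit of the assay and not a number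

Compound 3 stands at the limit of > 100000 nM in this assay, at which 1 of the 3 values shown sits, and so carries no number of its own. Compound 4 `CCCSc1nc2nc(C)cc(N3CC[C@@H](C)[C@@H](N(C)c4ncnc5[nH]ccc45)C3)n2n1` departs from compound 3 by one change (ethyl in place of vinyl on a saturated chain carbon bound to a sulfur), ethyl in place of vinyl on a saturated chain carbon bound to a sulfur, that is, allylsulfanyl to propylsulfanyl.

Going by the values given here, three measured steps bear on this. The nearest in kind, at the same place, is an at least 1.0-fold higher number from compound 2 to compound 3 (0.00 log units; that floor lies within the scatter) and it is small. Adding the sulfanyl chains to the shared core gave a 1.7-fold higher number from compound 1 to compound 2 (0.23 log units; within the scatter) and also an at least 1.7-fold higher number from compound 1 to compound 3 (0.23 log units; that floor lies within the scatter) in the same assay. None of these gives grounds for expecting a shift, so the expectation in this assay is an at least 1.0-fold lower number from compound 3 to compound 4 (0.02 log units; that floor lies within the scatter) and nothing beyond the scatter. A further limit rather than a number is also quite possible.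

For compound 4 the estimated value is 95000 nM with an expected range from 50000 nM to 150000 nM in this read-out.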

Compound 4, half-maximal inhibitory concentration: 67100 nM
Compound 4: middle estimate off by 1.4-fold (0.15 log units), on the high side, and the stated range covers the measured number.
By their numbers in this assay, from the lowest: compounds 1, 4 and 2 (each within the scatter of the next). At a limit, above all of these: compound 3.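

In this assay, propylsulfanyl in place of allylsulfanyl gives an at least 1.4-fold lower number from compound 3 to compound 4 (0.17 log units; that floor lies within the scatter) and so shows no shift beyond the scatter for this change on a saturated chain carbon bound to a sulfur. Compound 3 remains a limit of the assay and not a number: the limit of > 100000 nM in this assay, at which 1 of the 4 values shown sits. Compound 4 also stays within the scatter of both measured neighbours, with a 1.5-fold lower number from compound 2 to compound 4 (0.17 log units; within the scatter) for ethyl in place of cyclohexyl at the same place and a 1.2-fold higher number from compound 1 to compound 4 (0.06 log units; within the scatter) for propylsulfanyl in place of hydrogen on the shared core.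

Still open, on these data alone, is whether a sulfanyl chain ending in an amine or a carboxylic acid would move the number beyond the scatter in this assay on this core. As far as these compounds go, a longer straight chain at this place is equally open.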